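Pyridin-2-yl in Place of Furan-2-yl: An Expectation

The source may hold more compounds than are shown below. What is called first, only, known or untested is meant among the compounds shown, and "the series" means these compounds.

Compound 2 `COc1ccc(C(=O)/C=C/c2ccco2)c2c1C=CC(C)(C)O2` carries a furan-2-yl group on a double-bonded chain carbon bound to a double-bonded chain carbon. In a functional assay on HT-29 cells (Homo sapiens) for antiproliferative activity, read by MTT assay, with a stated time of 24 h (on this read-out higher numbers stand for weaker inhibition and lower numbers for stronger inhibition), compound 2 gives only a limit of the assay, > 10000 nM. Its closest neighbour, compound 1 `COc1ccc(C(=O)/C=C/c2cccc(F)c2)c2c1C=CC(C)(C)O2`, carries a 3-fluorophenyl group at that same place. In this assay compound 1 also gives only a limit, > 10000 nM. The step that the two limits leave unreadable from compound 1 to compound 2 is therefore unreadable, since both of its ends sit at the limit of > 10000 nM in this assay, at which 2 of the 2 values shown sit, and no size can be taken from it.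

Compound 3 `COc1ccc(C(=O)/C=C/c2ccccn2)c2c1C=CC(C)(C)O2` differs from compound 2 by pyridin-2-yl in place of furan-2-yl on a double-bonded chain carbon bound to a double-bonded chain carbon. For the measured compounds named here, no measured step bears directly on this change, and the single measured step that the two limits leave unreadable from compound 1 to compound 2 offers no readable size to lean on.

Because both measured compounds sit at the limit (the limit of > 10000 nM in this assay, at which 2 of the 2 values shown sit), compound 3 is expected to remain near that limit as well, with an estimated value of 15000 nM and a range from 4000 nM to 60000 nM. The estimated step that the limit leaves unreadable from compound 2 to compound 3 is thus expected to be none beyond the scatter, with the assay most likely again reporting only a limit.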

Compound 3, half-maximal inhibitory concentration: 2120 nM
For compound 3 the middle estimate is 7.1-fold (0.85 log units) above the measured one; measured number outside the range, below it.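

In this assay, for the compounds shown here, this place on the chain proves able to shift the read-out: pyridin-2-yl in place of furan-2-yl gives an at least 4.7-fold lower number from compound 2 to compound 3 (0.67 log units; beyond the scatter), the first step whose size can be read at all. Pyridin-2-yl in place of 3-fluorophenyl gives an at least 4.7-fold lower number from compound 1 to compound 3 (0.67 log units; beyond the scatter), so the lower number holds against both earlier groups, and compound 3 is the only one of the three compounds with a true number rather than a limit. Both steps give only a smallest possible size, not a full one, because each starts from a compound at a limit: the limit of > 10000 nM in this assay, at which 2 of the 3 values shown sit.

Going by these compounds, the step between compound 1 and compound 2 still cannot be read, so nothing shows how those two groups rank against each other, and the true size of the two new steps stays unknown. On these data alone, it also remains open whether the ring nitrogen of pyridin-2-yl is what matters here, a question that an unsubstituted phenyl group or a pyrimidine ring at the same place would help to answer.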